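Notes on the piperidine-ring change from compound 2 to compound 3

The compounds below may be only part of what the source reports. "The series", "measured", "known", "first", "only" and "open" are said of these compounds alone.

The series is followed in an assay on HEK293 cells for inhibition of sodium- and chloride-dependent glycine transporter 1 (Homo sapiens); a higher number here means a weaker inhibitor, a lower number a stronger inhibitor. Compound 1 `O=S(=O)(NC[C@H](O)CN1CCCC1C1CC1)c1cccc2ccccc12` carries a pyrrolidine bearing a cyclopropyl group and gives 501 nM; 1580 nM (2 entries) in this assay across its repeat entries, as shown in the several entries of compound 1 in this assay, 501 nM; 1580 nM (2 entries). Compound 2 `CCC1CCC(C)N(C[C@@H](O)CNS(=O)(=O)c2cccc3ccccc23)C1` gives 1000 nM in this assay; that is the only single number shown for it, and one further entry for compound 2 in this assay reports no single number. The values of compound 1 and compound 2 lie close to each other.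

Compound 3 `CCC1CCCCN1C[C@@H](O)CNS(=O)(=O)c1cccc2ccccc12` has not yet been measured in this assay. The change from compound 2 to compound 3 is 2-ethylpiperidin-1-yl in place of 5-ethyl-2-methylpiperidin-1-yl on a saturated chain carbon, two bonds along the chain from an oxygen on a saturated carbon. For the measured compounds named here, no measured step in this assay covers such a change, so the expectation rests on the closeness of compound 1 and compound 2 alone. The step from compound 2 to compound 3 in this assay is expected to be small, a 1.2-fold higher number from compound 2 to compound 3 (0.08 log units; within the scatter), with no direction beyond the scatter. Compound 3 is therefore estimated at 1200 nM in this assay, within 400 nM to 4000 nM.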

Compound 3, half-maximal inhibitory concentration: 7940 nM
For compound 3 the middle estimate is 6.6-fold (0.82 log units) below the measured one; the measured number lies above the stated range.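

In this assay, the group on a saturated chain carbon, two bonds along the chain from an oxygen on a saturated carbon, proves sensitive to how the piperidine is substituted: 2-ethylpiperidin-1-yl in place of 5-ethyl-2-methylpiperidin-1-yl gives a 7.9-fold higher number from compound 2 to compound 3 (0.90 log units; beyond the scatter). For the compounds shown here, this is the first step at this place that can be read, and it shows that these two substituted piperidines are not interchangeable here, even though both names differ only in the ring's alkyl groups. The step remains graded modest, and a single step deserves caution in a series whose repeat entries can lie well apart: the several entries of compound 1 in this assay, 501 nM; 1580 nM (2 entries).

The change from compound 2 to compound 3 alters two things at once, the loss of the methyl and the shift of the ethyl, so the compounds shown do not tell which of them accounts for the step. A 2-methylpiperidin-1-yl or a 5-ethylpiperidin-1-yl at the same place would separate the two, and an unsubstituted piperidin-1-yl would give the reference for both.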